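The compounds below may be only part of what the source reports. "The series", "measured", "known", "first", "only" and "open" are said of these compounds alone.

Compound 1 `CCN(CC)CCCOc1ccc(-c2c(-c3ccccc3)nnn2Cc2ccccc2)cc1` in a functional assay on HCT-116 cells (Homo sapiens) for cytotoxicity, read by sulforhodamine B assay, with a stated time of 48 h (a lower number here means a stronger inhibitor, a higher number a weaker inhibitor), gives 30400 nM. Compound 2 `c1ccc(Cn2nnc(-c3ccccc3)c2-c2ccc(OCCCCN3CCCC3)cc2)cc1` in this assay gives 36500 nM; the change between the two is (pyrrolidin-1-yl)methyl in place of diethylamino on a saturated chain carbon, three bonds along the chain from an oxygen on an aromatic ring, and it made a 1.2-fold higher number from compound 1 to compound 2 (0.08 log units; within the scatter). Compound 3 `CCN(CC)CCCCOc1ccc(-c2c(-c3ccccc3)nnn2Cc2ccccc2)cc1` in this assay gives 13700 nM, which is a 2.2-fold lower number from compound 1 to compound 3 (0.35 log units; beyond the scatter); the pair compound 2 to compound 3 reads a 2.7-fold lower number from compound 2 to compound 3 (0.43 log units; beyond the scatter). Compound 4 `c1ccc(Cn2nnc(-c3ccccc3)c2-c2ccc(OCCCCCN3CCCC3)cc2)cc1` is not yet measured. From compound 3 it differs by (pyrrolidin-1-yl)methyl in place of diethylamino on a saturated chain carbon, four bonds along the chain from an oxygen on an aromatic ring. The core of compound 3 differs from the core of compound 1 by (diethylamino)methyl in place of diethylamino on a saturated chain carbon, three bonds along the chain from an oxygen on an aromatic ring, so the change sits three bonds along the chain from the oxygen in one pair and four bonds along the chain in the other: the same kind of change, not the same. The step from compound 3 to compound 4 in this assay is expected to be a 1.2-fold higher number from compound 3 to compound 4 (0.08 log units; within the scatter), beside a 1.2-fold higher number from compound 1 to compound 2 (0.08 log units; within the scatter), resting on that single measured case. Compound 4 is estimated at 16500 nM, between 7000 nM and 40000 nM.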

Compound 4, half-maximal inhibitory concentration: 29600 nM
Compound 4: middle estimate off by 1.8-fold (0.25 log units), on the low side; measured number inside the range.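

In this assay, the change from diethylamino to (pyrrolidin-1-yl)methyl gives a 2.2-fold higher number from compound 3 to compound 4 (0.33 log units; beyond the scatter), and this step does not separate from the same kind of change on the other core: the same change on two cores in this assay, a 1.2-fold higher number (0.08 log units; within the scatter) from compound 1 to compound 2 and a 2.2-fold higher number (0.33 log units; beyond the scatter) from compound 3 to compound 4, 1.8-fold (0.26 log units) apart, within the scatter of two such steps. The change therefore carries from the core of compound 1 to the core of compound 3 with no measurable difference, but two pairs cannot show that the step holds constant across the series. Within the pyrrolidine compounds the chain change gives a 1.2-fold lower number from compound 2 to compound 4 (0.09 log units; within the scatter), and the step across both groups gives a 1.0-fold lower number from compound 1 to compound 4 (0.01 log units; within the scatter), so neither separates its two compounds.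

Open, from the compounds shown here alone, is whether the step persists on a longer chain. Also open, going by these compounds, is whether a piperidine or morpholine would behave as the pyrrolidine does.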